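Swapping Ethyl for Chloro on a Weak Inhibitor Series

The compounds below may be only part of what the source reports. "The series", "measured", "known", "first", "only" and "open" are said of these compounds alone.

Three close relatives of one shared core have been tested in a functional assay on HeLa cells (Homo sapiens) for inhibition; on this read-out lower numbers stand for stronger inhibition and higher numbers for weaker inhibition. Compound 1 `Cc1ccc(C(=O)CC(SCC(=O)O)C(=O)O)cc1C` gives 3810 nM, compound 2 `CCc1ccc(C(=O)CC(SCC(=O)O)C(=O)O)cc1` gives 4790 nM, and compound 3 `Cc1ccc(C(=O)CC(SCC(=O)O)C(=O)O)c(Cl)c1` gives 4730 nM. Compound 2 shows the highest of these three numbers, yet its gaps to compound 3 and to compound 1 both lie within the scatter, so no order among them can be claimed. Compound 4 `O=C(O)CSC(CC(=O)c1ccc(Cl)cc1)C(=O)O` differs from compound 2 in one place: chloro in place of ethyl on an aromatic carbon. Within the data shown here, no step between measured compounds resembles this exchange, so there is little to lean on. The expected step is a 1.1-fold lower number from compound 2 to compound 4 (0.03 log units; within the scatter), nothing beyond the scatter in either direction. In this assay compound 4 is estimated at 4500 nM, with a range from 2000 nM to 10000 nM.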

Compound 4, half-maximal inhibitory concentration: 17200 nM
Estimate against measurement, compound 4: 3.8-fold (0.58 log units) below; measured number above the stated range.
By their numbers in this assay, from the lowest: compounds 1, 3 and 2 (each within the scatter of the next); then compound 4.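

In this assay chloro in place of ethyl on an aromatic carbon para to a large group gives a 3.6-fold higher number from compound 2 to compound 4 (0.56 log units; beyond the scatter) and so moves the number beyond the scatter. The earlier compounds shown here, whose numbers lay within the scatter of one another, did not show that a change at this position can matter this much. Nothing at hand explains this rise.

Still open, on these data alone, is how other groups on this carbon would read, such as an amine, a methoxy group or a longer chain like propyl. With a single step at this position, no trend across groups can be drawn.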